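The compounds below may be only part of what the source reports. "The series", "measured", "known", "first", "only" and "open" are said of these compounds alone.

In a functional assay on the whole organism (Central nervous system) with Mus musculus as the target (on this read-out lower numbers stand for an effect already at smaller amounts and higher numbers for an effect only at larger amounts of compound), compound 1 `O=C(CCC(=O)c1ccc(Cl)c(Cl)c1)NCCCO` gives 500 mg/kg, and compound 2 `O=C(CCC(=O)c1ccc(Cl)cc1)NCCCO` gives 325 mg/kg. For the measured compounds named here, compound 2 therefore shows the lowest of the two numbers measured so far, but its nearest neighbour is compound 1, and the step from compound 1 to compound 2, a 1.5-fold lower number from compound 1 to compound 2 (0.19 log units; within the scatter) that comes from a hydrogen in place of chloro on an aromatic carbon, stays within the scatter of this assay.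

Compound 3 `Cc1ccc(C(=O)CCC(=O)NCCCO)cc1` has not yet been measured. It differs from compound 2 in one place: methyl in place of chloro on an aromatic carbon. Going by the values given here, the only measured step that touches a chloro on the aromatic ring is the one from compound 1 to compound 2, and that step did not move beyond the scatter. Among the compounds with values here, no measured pair shows a methyl entering in place of chloro, so there is nothing here that points to a change in either direction beyond the scatter in this assay.

Compound 3 is therefore expected to give about 325 mg/kg, within a range from 160 mg/kg to 650 mg/kg. Relative to compound 2 this estimate means a step of no change at the digits printed from compound 2 to compound 3 (within the scatter), expected to stay within the scatter.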

Compound 3, dose for half-maximal effect: 700 mg/kg
Beside the measured number, compound 3's estimate is 2.2-fold (0.33 log units) below it; the whole stated range lies below it.
By their numbers in this assay, from the lowest: compounds 2, 1 and 3 (each within the scatter of the next, the first and the last beyond it).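

In this assay, methyl in place of chloro on the aromatic carbon para to a large group gives a 2.2-fold higher number from compound 2 to compound 3 (0.33 log units; beyond the scatter) and is the only single-place step shown here that lies beyond the scatter, although the size of that step is modest. The count of what changes is small: one heavy atom leaves and one enters, with no ring, no hydrogen-bond donor or acceptor and no net charge on either side, so a swap this small can still shift the dose, whereas the earlier step, a 1.5-fold lower number from compound 1 to compound 2 (0.19 log units; within the scatter) with hydrogen in place of chloro, stayed within the scatter. Nothing measured here explains why methyl and chloro differ at this position.

Going by these compounds, this reading rests on a single pair, so it remains open whether the shift belongs to methyl alone or would also appear with fluoro, methoxy or trifluoromethyl at the same carbon. On these data alone, it is also open whether the same swap would give a similar step if the hydroxypropyl amide chain were replaced by a longer chain or an amine.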